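The source may report more compounds than this note shows. Statements on the series, on what has been measured and on what is new or still open speak of the compounds shown alone.

Of the compounds shown here, three with a shared core have been tested in a functional assay on MIA PaCa-2 cells (Homo sapiens) for inhibition, read by MTT assay, with a stated time of 48 h, tested at 10 uM (a lower number here means less inhibition of growth, a higher number more inhibition of growth at the concentration tested), and they differ only in the group on a saturated chain carbon bound to an aromatic carbon. Compound 1 `CCN(CC)Cc1c(O)c([C@H]2CCN(C)C[C@H]2O)c2oc(C)cc(=O)c2c1O`, carrying diethylamino, gives 27%. Compound 2 `CCOC(=O)N1CCN(Cc2c(O)c([C@H]3CCN(C)C[C@H]3O)c3oc(C)cc(=O)c3c2O)CC1`, carrying 4-(ethoxycarbonyl)piperazin-1-yl, gives 4%. Compound 3 `Cc1cc(=O)c2c(O)c(CN(C(C)C)C(C)C)c(O)c([C@H]3CCN(C)C[C@H]3O)c2o1`, carrying diisopropylamino, gives 11%. Compound 3 cannot be told apart from compound 2, with a number 7 percentage points higher from compound 2 to compound 3 (within the scatter), while compound 1 stands clearly higher.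

Compound 4 `Cc1cc(=O)c2c(O)c(CN3CC(O)CC3C(=O)O)c(O)c([C@H]3CCN(C)C[C@H]3O)c2o1` has 2-carboxy-4-hydroxypyrrolidin-1-yl in place of the diisopropylamino of compound 3: 2-carboxy-4-hydroxypyrrolidin-1-yl in place of diisopropylamino on a saturated chain carbon bound to an aromatic carbon. Two measured changes at this same place bear on it: a number 23 percentage points lower from compound 1 to compound 2 (beyond the scatter) and a number 16 percentage points lower from compound 1 to compound 3 (beyond the scatter). Both are modest, and both show a lower number once diethylamino is replaced. Among the compounds with values here, neither tells directly how the new group behaves, since no tested compound carries it. With only two such replacements to go on, the entering group is not expected to restore the level of compound 1, and the expectation stays close to the low results. The expected change is a number 1 percentage points lower from compound 3 to compound 4 (within the scatter), which would not stand out from the scatter. In this assay, the estimate for compound 4 is 10%, with an expected range from 0% to 25%.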

Compound 4, percent growth inhibition at one concentration: 23%
For compound 4 the middle estimate is 13 percentage points below the measured one, within the range that was stated.
By their numbers in this assay, from the lowest: compounds 2 and 3 (each within the scatter of the next); then compounds 4 and 1 (each within the scatter of the next).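

Earlier, both replacements of diethylamino at this place on a saturated chain carbon gave clear drops, but with a number 4 percentage points lower from compound 1 to compound 4 (within the scatter) in this assay the 2-carboxy-4-hydroxypyrrolidin-1-yl group cannot be told apart from diethylamino, so this position does not lose its level with every replacement. The new group also stands clearly above both weaker replacements, with a number 12 percentage points higher from compound 3 to compound 4 (beyond the scatter) and with a number 19 percentage points higher from compound 2 to compound 4 (beyond the scatter) as well, and since the 4-(ethoxycarbonyl)piperazin-1-yl group of compound 2 also holds a ring, a ring at this place does not by itself set the level. No supporting measurement is available to explain these differences.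

From the compounds shown here alone, it remains open which part of the new group matters, and a plain pyrrolidin-1-yl group, compared with versions carrying only the carboxylic acid or only the hydroxyl, would separate their contributions. Whether any amine here can rise clearly above diethylamino also stays unanswered, and a smaller dimethylamino group or a longer chain on the nitrogen, such as dipropylamino, would test that.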